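The source may report more compounds than this note shows. Statements on the series, on what has been measured and on what is new or still open speak of the compounds shown alone.

Values in an ADME assay (liver) for metabolic stability, with Liver microsome (Rattus norvegicus) as the target, read by LC-MS, using microsomes, with a stated time of 30 min, tested at 4 uM; on this read-out higher numbers stand for a more stable compound and lower numbers for a less stable compound:

- compound 1 `Cc1nc(N2CCN(C)CC2)c2nc(-c3ccccc3Cl)n(CCO)c2n1`: 6%
- compound 2 `CCN1CCN(c2nc(C)nc3c2nc(-c2ccccc2Cl)n3CCOC)CC1`: 53%
- compound 3 `COCCn1c(-c2ccccc2Cl)nc2c(N3CCN4C(=O)CCC4C3)nc(C)nc21`: 91%

Compound 1 stands lowest of the three, and both other compounds read higher by more than the usual scatter. Compound 4 `CC(=O)NCCn1c(-c2ccccc2Cl)nc2c(N3CCN(C)CC3)nc(C)nc21` has not yet been measured. It differs from compound 1 in one place, with acetamido in place of hydroxy on a saturated chain carbon, two bonds along the chain from an aromatic nitrogen. Put another way, 2-hydroxyethyl becomes 2-acetamidoethyl.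

Within the data shown here, the only measured step is a number 38 percentage points higher from compound 2 to compound 3 (beyond the scatter). It is large, but it concerns a group on an aromatic carbon, not this chain, so it shows only how far one change can move this assay in this series. Among the measured compounds shown here, no measured step tests the change itself, and any forecast is therefore loose.

Compound 1, at 6%, has little room to fall, while compound 2, at 53%, shows that much higher readings occur among these compounds. A moderate rise is therefore expected, and the expected change is a number 24 percentage points higher from compound 1 to compound 4 (beyond the scatter). For compound 4 the estimated value is 30%, with an expected range of 10% to 60%.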

Compound 4, percent of the compound remaining: 0%
Estimate against measurement, compound 4: 30 percentage points above, and the stated range ends above it.
By their numbers in this assay, from the lowest: compounds 4 and 1 (each within the scatter of the next); then compound 2; then compound 3.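

In this assay, among these compounds, the change from 2-hydroxyethyl to 2-acetamidoethyl gives a number 6 percentage points lower from compound 1 to compound 4 (within the scatter) and so offers the first direct reading of a change at this place, on a saturated chain carbon, two bonds along the chain from an aromatic nitrogen. Acetamido takes the place of hydroxy, yet on this read-out compound 1 and compound 4 cannot be told apart, and both sit low on the scale, so this swap does not lift the low reading of compound 1. Nothing measured here speaks to what lies behind this result.

The compounds shown leave open whether another end to this chain, such as an amine or a carboxylic acid, would read differently from hydroxy and acetamido. They also leave open whether the same swap would give a similar step in a compound that carries the group of compound 3 on the aromatic carbon, where the reading has more room to fall.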